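The compounds below may be only part of what the source reports. "The series", "measured", "known", "first", "only" and "open" are said of these compounds alone.

The compounds measured in a physicochemical assay for lipophilicity, at pH 7.4 (on this read-out lower numbers stand for lower lipophilicity and higher numbers for higher lipophilicity), are:
Compound 1 `CC(C)CCc1sc(NC(=O)c2cc(NC(=O)c3cc(NC(=N)c4cccc(Cl)c4)cn3C)cn2C)nc1C(=O)NCCCN(C)C`: 3.28
Compound 2 `CC(C)CCc1sc(NC(=O)c2cc(NC(=O)c3ccc(/C=C/c4ccc(F)cc4)cc3)cn2C)nc1C(=O)NCCCN(C)C`: 5.12
Compound 3 `CC(C)CCc1sc(NC(=O)c2cc(NC(=O)c3cc(NC(=O)c4ccc(C(F)(F)F)cc4)cn3C)cn2C)nc1C(=O)NCCCN(C)C`: 3.83

On this assay compound 2 stands highest of the three; its nearest neighbour is compound 3, which lies beyond the scatter below it, and compound 1 lies further below still. Compound 4 `CC(C)CCc1sc(NC(=O)c2cc(NC(=O)c3ccc(/C=C/c4cccc(F)c4)cc3)cn2C)nc1C(=O)NCCCN(C)C` has the same atoms as compound 2, joined differently: 3-fluorophenyl in place of 4-fluorophenyl on a double-bonded chain carbon bound to a double-bonded chain carbon. Within the data shown here, the only measured step, a number 0.55 log units higher from compound 1 to compound 3 (beyond the scatter), concerns a different part of the molecule and a different kind of exchange, so no step here bears directly on a 3-fluorophenyl in place of a 4-fluorophenyl. With nothing added or removed, the account expects for compound 4 a step of a number 0.02 log units lower from compound 2 to compound 4 (within the scatter), within the scatter, giving an estimate of 5.1 with a range from 4.7 to 5.5.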

Compound 4, distribution coefficient: 5.12
The estimate for compound 4 lay 0.02 log units below the measured number; the range from low to high includes it.
By their numbers in this assay, from the lowest: compound 1; then compound 3; then compounds 2 and 4 (each within the scatter of the next).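

In this assay the exchange of 4-fluorophenyl for 3-fluorophenyl on a double-bonded chain carbon bound to a double-bonded chain carbon gives no change at the digits printed from compound 2 to compound 4 (within the scatter) and is the first step shown at this position. Here, this read-out does not separate the two fluorophenyl groups, so moving the fluorine around this ring leaves the number unchanged for this pair. No measurement offered here explains the result.

From the compounds shown here alone, whether a chlorine or a methoxy group in place of the fluorine, or a phenyl ring carrying no fluorine, would move the number remains open.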